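Swapping the Ring on the Sulfur-Linked Chain Carbon

The compounds below may be only part of what the source reports. "The series", "measured", "known", "first", "only" and "open" are said of these compounds alone.

Compound 1 `N#Cc1c(N)nc(SCc2nnn[nH]2)c(C#N)c1-c1ccc(OCC2CC2)cc1`: 1%
Compound 2 `N#Cc1c(N)nc(SCn2cncn2)c(C#N)c1-c1ccc(OCC2CC2)cc1`: 1%
Compound 3 `N#Cc1c(N)nc(SCc2cccnc2)c(C#N)c1-c1ccc(OCC2CC2)cc1`: 19%

All three numbers come from an assay on CHO cells for displacement of a labelled ligand from adenosine receptor A3 (Homo sapiens), read by scintillation counting, with a stated time of 120 min, tested at 1 uM; a higher number here means more inhibition at the concentration tested (going by the name of the read-out), a lower number less inhibition. The compounds share one core and differ only in the aromatic ring attached to a saturated chain carbon bound to a sulfur. Compound 3 stands highest of the three: the step of a number 18 percentage points higher from compound 1 to compound 3 (beyond the scatter) and the step of a number 18 percentage points higher from compound 2 to compound 3 (beyond the scatter) are both beyond the scatter, while no change at the digits printed from compound 1 to compound 2 (within the scatter).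

Compound 4 `N#Cc1c(N)nc(SCc2cnc[nH]2)c(C#N)c1-c1ccc(OCC2CC2)cc1` differs from compound 3 in one place: 1H-imidazol-5-yl in place of pyridin-3-yl on a saturated chain carbon bound to a sulfur

The two steps that bear on this change both ran the other way, from an azole to pyridin-3-yl, and each was modest in size, a number 18 percentage points higher from compound 1 to compound 3 (beyond the scatter) and a number 18 percentage points higher from compound 2 to compound 3 (beyond the scatter). Returning from pyridin-3-yl to an azole, here 1H-imidazol-5-yl, is therefore expected to give a step of about the same size downward in this assay, a number 15 percentage points lower from compound 3 to compound 4 (beyond the scatter). Compound 4 is estimated at 4% in this assay, within a range from 0% to 18%.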

Compound 4, a percentage reported as inhibition, at one concentration (the size of the read-out at that concentration, not a potency): 1%
For compound 4 the middle estimate is 3 percentage points above the measured one; the measured number falls inside the stated range.
By their numbers in this assay, from the lowest: compounds 1, 2 and 4 (each within the scatter of the next); then compound 3.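

Replacing pyridin-3-yl with 1H-imidazol-5-yl gives a number 18 percentage points lower from compound 3 to compound 4 (beyond the scatter) in this assay, so a third azole now falls below the pyridine compound. The azoles themselves cannot be told apart here, with no change at the digits printed from compound 2 to compound 4 (within the scatter) and no change at the digits printed from compound 1 to compound 4 (within the scatter). Among these four compounds, then, the only six-membered aromatic ring, pyridin-3-yl, stands apart from the three five-membered ones, although no measurement shown here explains this difference.

On these data alone, it remains open whether ring size itself matters, which phenyl or pyridin-4-yl on the same chain carbon could help to test. Also open, as far as these compounds go, is whether a non-aromatic group there, such as a carboxylic acid or an amine on a longer chain, would raise the number above that of compound 3.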